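A few compounds are considered here, and "the series" means these few. Any claim that something is new, unique, unknown or untested is made for them only; others in the source may bear on it.

Compounds measured so far:
compound 1 `CCOC(=O)[C@@]1(C(=O)Nc2ccccc2Cl)C[C@H]1c1cc(OC)c(OC)c(OC)c1`, > 100000 nM
compound 2 `COc1cc([C@@H]2C[C@@]2(CO)C(=O)Nc2ccccc2Cl)cc(OC)c1OC`, 18400 nM

In a functional assay on K562 cells (Homo sapiens) for cytotoxicity, read by MTT assay, with a stated time of 48 h (a higher number here means a weaker inhibitor, a lower number a stronger inhibitor), compound 1 gives > 100000 nM, and this is a limit of the assay rather than a measured number. Among the measured compounds shown here, the one recorded step, an at least 5.4-fold lower number from compound 1 to compound 2 (0.73 log units; beyond the scatter), swaps a hydroxymethyl for an ethoxycarbonyl on a saturated ring carbon. Compound 1 stands at the weak end of what has been seen, at the limit of > 100000 nM in this assay, at which 1 of the 2 values shown sits, so its true value is open upward.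

Compound 3 `CCOC(=O)[C@@]1(C(=O)Nc2ccccc2Cl)C[C@@H]1c1cc(OC)c(OC)c(OC)c1` has not yet been tested. It differs from compound 1 only in the sense of one stereocentre: the two compounds have the same atoms and bonds and differ only in configuration as drawn: 1 of 2 stereo elements differ; a stereocentre at a saturated ring carbon is drawn S in compound 1 and R in compound 3. For the measured compounds named here, no measured step concerns a change of configuration alone; the single step from compound 1 to compound 2 alters a substituent and therefore does not bear on this change. With nothing to lean on, the expectation for compound 3 is a step of an at least 1.2-fold lower number from compound 1 to compound 3 (0.09 log units; that floor lies within the scatter) in this assay, that is, no confident move in either direction. Compound 3 is therefore estimated at 80000 nM, within a range from 20000 nM to 300000 nM.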

Compound 3, half-maximal inhibitory concentration: 49400 nM
Compound 3: the middle estimate sits 1.6-fold (0.21 log units) above what was measured; measured number inside the range.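

Among the compounds shown here, changing only the stereocentre at a saturated ring carbon from S to R gives an at least 2.0-fold lower number from compound 1 to compound 3 (0.30 log units; that floor lies within the scatter) in this assay, the first step here that isolates configuration, and its floor alone does not establish a real difference between the two forms. The true size of the step cannot be fixed, because one end of it is a limit of the assay and not a number: the limit of > 100000 nM in this assay, at which 1 of the 3 values shown sits. Even so, compound 3 gives a measured number where its partner gives only a limit, and any gap between them can come only from the drawn configuration, because nothing else separates the pair: the fact that compounds 1 and 3 differ only in the configuration as drawn.

The compounds shown leave open whether the same change of configuration would matter with hydroxymethyl in place of ethoxycarbonyl, and what changing the other stereocentre would do. Also open, from the compounds shown here alone, is how a carboxylic acid in place of the ethoxycarbonyl would read at this ring carbon, in either configuration.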